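This account rests on a few compounds, and the source may have more. Where it says the series, first, only, none or still open, it means among the compounds named here.

Measured compounds:
- compound 1 `CCN(Cc1ccncc1)C(=S)SCc1ccc(C(=O)Nc2ccccc2N)cc1`: 86.2%
- compound 2 `Nc1ccccc1NC(=O)c1ccc(CSC(=S)N2CCN(c3ccncc3)CC2)cc1`: 90.7%
- compound 3 `Nc1ccccc1NC(=O)c1ccc(CSC(=S)N2CCN(c3ccc(F)cc3)CC2)cc1`: 76.3%

In a functional assay on A-375 cells (Homo sapiens) for antiproliferative activity, read by CCK-8 assay, with a stated time of 72 h, tested at 8 uM (a higher number here means a stronger effect of the compound at the concentration tested, a lower number a weaker effect), compound 1 gives 86.2%, the second highest of the three numbers. Compound 2 gives 90.7%, which lies within the scatter of compound 1, and compound 3 gives 76.3%, also within the scatter of compound 1. Among the measured compounds shown here, the one measured step, a number 14.4 percentage points lower from compound 2 to compound 3 (beyond the scatter), is the only change that goes beyond the scatter.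

Compound 4 `Nc1ccccc1NC(=O)c1ccc(CSC(=S)N2CCCC2)cc1` has not yet been measured in this assay. It differs from compound 1 in one place: pyrrolidin-1-yl in place of ethyl((pyridin-4-yl)methyl)amino on a thiocarbonyl carbon. For the measured compounds named here, no measured step matches this change directly. The step from compound 2 to compound 3 bears on it only loosely, in that a pyridin-4-yl group leaves there as well, and it lowered the number by a modest amount. A step of similar or smaller size downward is therefore expected, though the scatter of the assay means it may not show at all. Compound 4 is estimated to give 77% in this assay, within a range from 60% to 92%, which means an expected step of a number 9.2 percentage points lower from compound 1 to compound 4 (within the scatter).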

Compound 4, a percentage reported as inhibition, at one concentration (the size of the read-out at that concentration, not a potency): 89.5%
For compound 4 the middle estimate is 12.5 percentage points below the measured one; the range from low to high includes it.
By their numbers in this assay, from the lowest: compounds 3, 1, 4 and 2 (each within the scatter of the next, the first and the last beyond it).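

In this assay, pyrrolidin-1-yl in place of ethyl((pyridin-4-yl)methyl)amino on the thiocarbonyl carbon gives a number 3.3 percentage points higher from compound 1 to compound 4 (within the scatter). The thiocarbonyl carbon therefore tolerates this exchange in this assay: the six-membered aromatic ring with its hetero atom can leave, and a five-membered non-aromatic ring can stand in place of the group that held it, without a change beyond the scatter. The read-out comes from a single concentration. It shows that the effects of the two compounds are alike at that concentration, and it tells nothing about their effects at any other concentration.

As far as these compounds go, it remains open whether a piperidine, a morpholine or an open-chain diethylamino group on the same carbon would give a similar read-out, and whether compound 1 and compound 4 would separate at lower concentrations. Nothing available explains why the exchange leaves the read-out within the scatter.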